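From methoxy to trifluoromethyl: one swap on compound 2

A few compounds are considered here, and "the series" means these few. Any claim that something is new, unique, unknown or untested is made for them only; others in the source may bear on it.

Of the compounds shown here, two have been tested so far in a functional assay on V79 cells (Cricetulus griseus) for cytotoxicity, read by colony formation; a lower number here means a stronger inhibitor, a higher number a weaker inhibitor. Compound 1 (`NC1CCN(c2c(F)cc3c(=O)c(C(=O)O)cn(C4CC4)c3c2C(F)(F)F)C1`) has three entries, 300 ug/mL; 300 ug/mL; 300 ug/mL (3 entries), so it has no single reading. Within the data shown here, compound 2 (`COc1c(N2CCCC(N)C2)c(F)cc2c(=O)c(C(=O)O)cn(C3CC3)c12`) gives 69 ug/mL, the only single number available, and this is the starting point here.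

Compound 3 (`NC1CCCN(c2c(F)cc3c(=O)c(C(=O)O)cn(C4CC4)c3c2C(F)(F)F)C1`) has not yet been measured. It keeps the 3-aminopiperidin-1-yl group of compound 2 but has trifluoromethyl in place of methoxy on an aromatic carbon.

Among the measured compounds shown here, no measured pair shows this swap on its own, so the data give no direct size for the step. For the measured compounds named here, the only loose guide is compound 1, the one measured compound with trifluoromethyl, which gives 300 ug/mL; 300 ug/mL; 300 ug/mL (3 entries), a higher number than that of compound 2, 69 ug/mL. In this assay, a shift toward weaker inhibition, somewhat beyond the usual scatter, is therefore expected, with an estimated step of a 2.2-fold higher number from compound 2 to compound 3 (0.34 log units; beyond the scatter). The estimated value for compound 3 is 150 ug/mL, with an expected range from 60 ug/mL to 350 ug/mL.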

Compound 3, half-maximal inhibitory concentration: > 500 ug/mL
Compound 3: only a limit was reported (the forecaster's own chance of this, stated with the estimate: 25%); at least 3.3-fold (0.52 log units) between middle value and limit.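

In this assay, trifluoromethyl in place of methoxy on this aromatic carbon, ortho to a 3-aminopiperidin-1-yl group, can now be read as a single change, and it gives an at least 7.2-fold higher number from compound 2 to compound 3 (0.86 log units; beyond the scatter). This shows that the group at this position matters on the shared core, with the change going toward weaker inhibition and beyond the usual scatter.

Compound 3 gives > 500 ug/mL, which is a limit and not a number.

The step is therefore only a minimum, and its true size stays unknown, because the reading for compound 3 stops at a limit: the limit of > 500 ug/mL in this assay, at which 1 of the 3 values shown sits.

With only methoxy and trifluoromethyl compared at this carbon, the compounds shown cannot tell whether methoxy raises inhibition or trifluoromethyl lowers it. A plain hydrogen, a chlorine or an ethoxy group at the same place, with the 3-aminopiperidin-1-yl group kept, would help to separate these two readings and show how the number moves across a wider set of groups.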